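This account rests on a few compounds, and the source may have more. Where it says the series, first, only, none or still open, it means among the compounds named here.

In a functional assay on MOLT-4 cells (Homo sapiens) for cytotoxicity (a lower number here means that less compound is tolerated, a higher number that more compound is tolerated), three compounds sharing one core have been measured. Compound 1 `COc1nc(N)nc2c1ncn2C1CC(O)C(CO)S1`, with methoxy, gives 2000 nM. Compound 2 `Nc1nc(OCC2CC2)c2ncn(C3CC(O)C(CO)S3)c2n1`, with cyclopropylmethoxy, gives 13000 nM. Compound 3 `C=CCNc1nc(N)nc2c1ncn2C1CC(O)C(CO)S1`, with allylamino, gives 40000 nM, the highest of the three numbers.

The next step leads to compound 4 `CN(c1nc(N)nc2c1ncn2C1CC(O)C(CO)S1)C1CC1`, which has cyclopropyl(methyl)amino in place of allylamino on an aromatic carbon. Within the data shown here, three measured steps bear on it only indirectly. Allylamino in place of an oxygen-linked group gave a 20-fold higher number from compound 1 to compound 3 (1.30 log units; beyond the scatter) and a 3.1-fold higher number from compound 2 to compound 3 (0.49 log units; beyond the scatter), while cyclopropyl in place of hydrogen on the oxygen-linked chain gave a 6.5-fold higher number from compound 1 to compound 2 (0.81 log units; beyond the scatter). Among the measured compounds shown here, compound 4 retains a nitrogen-linked group, as compound 3 does, and no measured step exchanges one such group for another. No step beyond the scatter is therefore expected, with only a slight lean towards a lower number. The estimated step is a 1.6-fold lower number from compound 3 to compound 4 (0.20 log units; within the scatter). For compound 4, the expected value is 25000 nM, with an estimated range from 7000 nM to 80000 nM.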

Compound 4, half-maximal cytotoxic concentration: 100000 nM
Estimate against measurement, compound 4: 4.0-fold (0.60 log units) below; measured number outside the range, above it.
By their numbers in this assay, from the lowest: compound 1; then compound 2; then compound 3; then compound 4.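

In this assay, one nitrogen-linked group replacing another on this aromatic carbon still moves the number: cyclopropyl(methyl)amino in place of allylamino gives a 2.5-fold higher number from compound 3 to compound 4 (0.40 log units; beyond the scatter), so the position remains responsive among nitrogen-linked groups and not only between oxygen-linked and nitrogen-linked ones. The same entering group in place of the oxygen-linked groups gives a 7.7-fold higher number from compound 2 to compound 4 (0.89 log units; beyond the scatter) and a 50-fold higher number from compound 1 to compound 4 (1.70 log units; beyond the scatter), which places cyclopropyl(methyl)amino highest of the four groups compared here. Nothing measured here accounts for these steps.

The change adds a three-membered ring and a methyl group on the nitrogen, and the enteringgroup has no hydrogen-bond donor, so the compounds shown do not separate these features. On these data alone, whether cyclopropylamino or dimethylamino at this position would give a similar number remains open.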